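This account rests on a few compounds, and the source may have more. Where it says the series, first, only, none or still open, it means among the compounds named here.

Going by the values given here, compound 2 `CC(C)n1nc(-c2ccc3oc(N)nc3c2)c2c(N)nc(N)nc21` is one of two compounds measured in an ADME assay on cells (Hepatocyte, Homo sapiens) for metabolic stability, read by LC-MS, with a stated time of 90 min, tested at 1 uM; on this read-out lower numbers stand for slow clearance and higher numbers for fast clearance. Compound 2 reaches only a limit, < 5 uL/min. Compound 1 `CC(C)n1nc(-c2ccc3oc(N)nc3c2)c2c(F)nc(N)nc21` gives 57 uL/min in this assay. Among the compounds with values here, the one measured step, an at least 11-fold lower number from compound 1 to compound 2 (1.05 log units; beyond the scatter), ends at the limit of < 5 uL/min in this assay, at which 1 of the 2 values shown sits, so its full size is not known. Compound 3 `CC(C)n1nc(-c2ccc3oc(N)nc3c2)c2cnc(N)nc21` differs from compound 2 by hydrogen in place of amino on an aromatic carbon; this takes away the group the measured step brought in, though hydrogen rather than fluoro enters, so a move back toward compound 1 is expected. For compound 3 the expected step is an at least 3.6-fold higher number from compound 2 to compound 3 (0.55 log units; beyond the scatter). The estimate for compound 3 is 18 uL/min, with a range of 5 uL/min to 50 uL/min.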

Compound 3, intrinsic clearance in a liver preparation (reported as CLH), per the amount of preparation that the assay uses in the Hepatocyte assay: 150 uL/min
Beside the measured number, compound 3's estimate is 8.3-fold (0.92 log units) below it; measured number outside the range, above it.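

In the Hepatocyte assay the step of a 2.6-fold higher number from compound 1 to compound 3 (0.42 log units; beyond the scatter) puts hydrogen above fluoro at this position, and the step of an at least 30-fold higher number from compound 2 to compound 3 (1.47 log units; beyond the scatter) is larger, so the low number of compound 2 goes with amino and not merely with the absence of fluoro. Compound 2 gives < 5 uL/min there, which is a limit. In a physicochemical assay for solubility, read by HPLC, in phosphate buffer, measured as kinetic solubility, with a stated time of 24 h, at 20 degrees C, at pH 7.4, tested at 100 uM (on this read-out higher numbers stand for higher solubility and lower numbers for lower solubility), compound 2 gives 88000 nM and compound 3 gives 1600 nM here, so compound 2 holds both the lower clearance number and the higher solubility number.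

Open, from the compounds shown here alone, is whether a methylamino, dimethylamino or methoxy group at this position would keep either reading of compound 2.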